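Cytotoxicity of Three Analogues and a Nitro Variant

The source may hold more compounds than are shown below. What is called first, only, known or untested is meant among the compounds shown, and "the series" means these compounds.

Compound 1, `COC(=O)c1cc(-c2cccc(NC(=O)c3ccc(/C=C/C(=O)c4ccc(Br)cc4)cc3)c2)on1`, gives > 20 ug/mL in an ADME assay on Vero cells (Chlorocebus sabaeus) for cytotoxicity, read by MTT assay, with a stated time of 72 h (on this read-out lower numbers stand for higher toxicity in this test and higher numbers for lower toxicity in this test), a limit of the assay rather than a number.
Compound 2, `COC(=O)c1cc(-c2cccc(NC(=O)c3ccc(/C=C/C(=O)c4cccc(Br)c4)cc3)c2)on1`, gives > 100 ug/mL in this assay, again a limit.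
Compound 3, `COC(=O)c1cc(-c2cccc(NC(=O)c3ccc(/C=C/C(=O)c4ccccc4Cl)cc3)c2)on1`, gives > 25 ug/mL in this assay, also a limit.

Compound 3 thus stands only at a limit, and the two other values shown are limits as well (the limit of > 100 ug/mL in this assay, at which 1 of the 3 values shown sits, (the limit of > 20 ug/mL in this assay, at which 1 of the 3 values shown sits), (the limit of > 25 ug/mL in this assay, at which 1 of the 3 values shown sits)). The steps among the measured compounds, a step that the two limits leave unreadable from compound 1 to compound 2, a step that the two limits leave unreadable from compound 1 to compound 3 and a step that the two limits leave unreadable from compound 2 to compound 3, cannot be sized: none of the three limits shows a readable difference. Compound 4, `COC(=O)c1cc(-c2cccc(NC(=O)c3ccc(/C=C/C(=O)c4cccc([N+](=O)[O-])c4)cc3)c2)on1`, differs from compound 3 by 3-nitrophenyl in place of 2-chlorophenyl on a carbonyl carbon. Among the measured compounds shown here, all three measured steps bear on this change only in that each variant on the carbonyl carbon left the value at a limit; no step gives a direction or a size beyond the scatter. The expectation for compound 4 is therefore no readable step in this assay, with a step that the limit leaves unreadable from compound 3 to compound 4 taken as flat. Compound 4 is accordingly estimated at 60 ug/mL, in a range from 20 ug/mL to 200 ug/mL, and most likely it will again be reported as a limit.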

Compound 4, half-maximal cytotoxic concentration: > 40 ug/mL
Compound 4 gave a limit, no number; the forecaster's own chance of this, stated with the estimate: 70%; the middle value is on the limit's open side.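

Compound 4 gives > 40 ug/mL in this assay, which is a limit and not a number. Its steps to compound 1, compound 2 and compound 3 therefore cannot be read. The compounds shown leave open what value any of the four would reach in this assay, and whether the aryl group on the carbonyl carbon affects it.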